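This account rests on a few compounds, and the source may have more. Where it says the series, first, only, none or still open, it means among the compounds named here.

Measured compounds:
compound 1, `CCC(C)C1NC(=O)N(C2CCCCC2)C1=O`: > 100 ug/mL
compound 2, `CCC(C)C1NC(=O)N(C2CCCC2)C1=O`: > 100 ug/mL
compound 3, `CCC(C)C(NC(=O)n1nnc2ccccc21)C(=O)NCc1ccccc1`: 200 ug/mL

All three were tested in a functional assay on HEL cells (Homo sapiens) for cytotoxicity; on this read-out lower numbers stand for higher toxicity in this test and higher numbers for lower toxicity in this test. For compound 1 the value > 100 ug/mL is a limit of the assay rather than a number. Compound 2 likewise gives only a limit, > 100 ug/mL. Compound 3 gives a measured number, 200 ug/mL. Compound 1 therefore stands at the limit of > 100 ug/mL in this assay, at which 2 of the 3 values shown sit, and nothing more precise about it is known. Going by the values given here, no two of the measured compounds differ in a single place, so no measured step is available to guide the next change.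

The compound not yet measured is compound 4, `CC(C)C1NC(=O)N(C2CCCCC2)C1=O`. It differs from compound 1 by hydrogen in place of methyl on a saturated chain carbon, two bonds along the chain from a saturated ring carbon. The rest of the shared core stays as it is in compound 1. Among the compounds with values here, with no measured step of this kind and only a limit for compound 1, the reasonable expectation in this assay is a step of none beyond the scatter. The expected step is a step that the limit leaves unreadable from compound 1 to compound 4. For compound 4 the estimate is 120 ug/mL, within a range from 60 ug/mL to 400 ug/mL, and the result is expected most often to come back as a limit again.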

Compound 4, minimum cytotoxic concentration: >= 100 ug/mL
Compound 4: only a limit was reported; the forecaster's own chance of this, stated with the estimate: 85%; the middle value lies beyond the limit too.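

Going by these compounds alone, compound 1 and compound 4 both return only limits of the assay in this assay, not numbers, so no step between them can be read. The compounds shown leave open where the true values of these two compounds lie, and whether the change from sec-butyl to isopropyl alters toxicity in this test at all.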